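The source may hold more compounds than are shown below. What is called first, only, known or untested is meant among the compounds shown, and "the series" means these compounds.

Series notes. The shared core carries a phenyl-bearing chain on one side and a varied aromatic group on the other. In an assay (Rattus norvegicus) for inhibition of Fatty-acid amide hydrolase 1 (Homo sapiens) (on this read-out lower numbers stand for stronger inhibition and higher numbers for weaker inhibition), compound 1 `N#Cc1ccccc1-c1cnc(C(=O)CCCCCCc2ccccc2)o1` gives 130 nM, compound 2 `Nc1cccc(-c2cnc(C(=O)CCCCCCc3ccccc3)o2)c1` gives 19 nM, and compound 3 `O=C(CCCCCCc1ccccc1)c1ncc(-c2ccc(F)cc2)o1` gives 62 nM. Compound 3 stands second highest of the three numbers in this assay: a 2.1-fold lower number from compound 1 to compound 3 (0.32 log units; beyond the scatter) and a 3.3-fold higher number from compound 2 to compound 3 (0.51 log units; beyond the scatter). The widest swing among the measured aromatic groups is a 6.8-fold lower number from compound 1 to compound 2 (0.84 log units; beyond the scatter).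

Compound 4 `Cc1ccc(-c2cnc(C(=O)CCCCCCc3ccccc3)o2)nc1` differs from compound 3 by 5-methylpyridin-2-yl in place of 4-fluorophenyl on an aromatic carbon. Among the compounds with values here, no measured step exchanges a carbon-only aromatic ring for one containing a ring nitrogen, so the three measured steps bear on it only as a measure of how far this position has moved the number so far, all of them modest. A step of modest size is therefore expected in this assay, with no clear direction. For compound 4 the expected step is a 1.1-fold lower number from compound 3 to compound 4 (0.05 log units; within the scatter), giving an estimate of 55 nM with a range from 15 nM to 200 nM.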

Compound 4, inhibition constant: 2.8 nM
For compound 4 the middle estimate is 20-fold (1.29 log units) above the measured one; the measured number lies below the stated range.
By their numbers in this assay, from the lowest: compound 4; then compound 2; then compound 3; then compound 1.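

In this assay, the 5-methylpyridin-2-yl group moves the number further than any exchange among the three carbon-only aromatic rings did: the steps to compound 4 are large from the fluorophenyl compound (a 22-fold lower number from compound 3 to compound 4 (1.35 log units; beyond the scatter)) and from the cyanophenyl compound (a 46-fold lower number from compound 1 to compound 4 (1.67 log units; beyond the scatter)), where all earlier steps at this position were modest. Even against the previous lowest number the step stays beyond the scatter (a 6.8-fold lower number from compound 2 to compound 4 (0.83 log units; beyond the scatter)), so this position has more range than the first three compounds showed, and the only ring here with a hetero atom gives the lowest number of the four. Nothing measured on hand accounts for this gain.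

Going by these compounds, the exchange brings in the ring nitrogen and the methyl together, so the share of each stays open. A plain pyridyl ring and a methylphenyl ring at this position would separate the two.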